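The source may hold more compounds than are shown below. What is called first, only, known or untested is meant among the compounds shown, and "the series" means these compounds.

Measured in a functional assay on HeLa cells (Homo sapiens) for antiproliferative activity, read by MTT assay, with a stated time of 48 h; a higher number here means a weaker inhibitor, a lower number a stronger inhibitor:
- compound 1 `Cc1cc2c(c(=O)n1C)C(c1ccc(N(C)C)c(Br)c1)C(C#N)=C(N)O2`: 330 nM
- compound 2 `Cc1cc2c(c(=O)n1C)C(c1ccc(F)c(Br)c1)C(C#N)=C(N)O2`: 6330 nM
- compound 3 `Cc1cc2c(c(=O)n1C)C(c1cccc(Br)c1)C(C#N)=C(N)O2`: 6500 nM

Compound 3 lies within the scatter of compound 2, as a 1.0-fold higher number from compound 2 to compound 3 (0.01 log units; within the scatter) shows, and both stand well above compound 1. That gap is a 20-fold higher number from compound 1 to compound 3 (1.29 log units; beyond the scatter).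

Next in the series is compound 4 `Cc1cc2c(c(=O)n1C)C(c1cccc([N+](=O)[O-])c1)C(C#N)=C(N)O2`, with nitro in place of bromo on an aromatic carbon, meta to a large group: nitro in place of bromo on an aromatic carbon.

For the measured compounds named here, no measured step changes the bromo group itself, since compounds 1, 2 and 3 all carry it, so the evidence is indirect. Going by the values given here, the only large steps are those that remove dimethylamino, namely a 19-fold higher number from compound 1 to compound 2 (1.28 log units; beyond the scatter) and a 20-fold higher number from compound 1 to compound 3 (1.29 log units; beyond the scatter). Compound 4 has no dimethylamino group, so it shares that feature with compound 2 and compound 3. Among the compounds with values here, the one step without dimethylamino on either side, hydrogen in place of fluoro, is a 1.0-fold higher number from compound 2 to compound 3 (0.01 log units; within the scatter). That single flat step is thin support, and the data do not show how the series responds to nitro.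

The expected step in this assay stays within the scatter and has no firm direction: a 1.3-fold lower number from compound 3 to compound 4 (0.11 log units; within the scatter). The estimate for compound 4 is 5000 nM, with an expected range of 1500 nM to 17000 nM.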

Compound 4, half-maximal inhibitory concentration: 35000 nM
Estimate against measurement, compound 4: 7.0-fold (0.85 log units) below; measured number above the stated range.
By their numbers in this assay, from the lowest: compound 1; then compounds 2 and 3 (each within the scatter of the next); then compound 4.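

Read in this assay, the aromatic carbon that carries bromo, meta to a large group, is no longer a silent position: nitro in place of bromo gives a 5.4-fold higher number from compound 3 to compound 4 (0.73 log units; beyond the scatter), a step beyond the scatter. For the compounds shown here, this is the first measured change at this carbon, since compounds 1, 2 and 3 all keep bromo, and it shows that bromo cannot be exchanged for nitro here without a loss in this read-out. No measurement at hand on these compounds accounts for the step.

As far as these compounds go, a single pair cannot separate what nitro adds from what the loss of bromo removes, so it remains open how the number would respond to a smaller or differently built group at this carbon, such as chloro, methoxy or a simple amine. Also open, from the compounds shown here alone, is whether dimethylamino, the group on compound 1, would keep its large effect with nitro rather than bromo at this carbon, and whether a group such as a carboxylic acid would be tolerated here at all.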